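The source may hold more compounds than are shown below. What is called first, only, known or untested is meant among the compounds shown, and "the series" means these compounds.

Measured in a functional assay on HL-60 cells (Homo sapiens) for antiproliferative activity, read by MTT assay; on this read-out higher numbers stand for weaker inhibition and lower numbers for stronger inhibition:
Compound 1 `O[C@@H]1[C@@H](OCc2ccccc2)[C@H](O)[C@@H](COCc2ccccc2)O[C@H]1Cc1ccccc1`: 35300 nM
Compound 2 `O[C@@H]1[C@@H](OCc2ccccc2)[C@H](OCc2ccccc2)[C@@H](COCc2ccccc2)O[C@H]1Cc1ccccc1`: 8700 nM
Compound 3 `OC[C@H]1O[C@@H](Cc2ccccc2)[C@H](O)[C@@H](OCc2ccccc2)[C@@H]1OCc1ccccc1`: 20200 nM

Compound 3 holds the middle place of the three numbers. It lies within the scatter of compound 1 and clearly above compound 2. Compound 4 `OC[C@H]1O[C@@H](Cc2ccccc2)[C@H](O)[C@@H](OCc2ccccc2)[C@@H]1O` differs from compound 3 by one change, benzyloxy to hydroxy: hydrogen in place of benzyl on an oxygen on a saturated carbon. Two measured steps exchange the same groups. Adding benzyl gave a 4.1-fold lower number from compound 1 to compound 2 (0.61 log units; beyond the scatter), and removing it gave a 2.3-fold higher number from compound 2 to compound 3 (0.37 log units; beyond the scatter). Both are modest but beyond the scatter, so a modest rise in the number is expected. The estimated step is a 2.7-fold higher number from compound 3 to compound 4 (0.44 log units; beyond the scatter). For compound 4 the expected value is 55000 nM, with an estimated range of 25000 nM to 120000 nM.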

Compound 4, half-maximal inhibitory concentration: "not active" (no number reported)
Compound 4: no number reported; there is nothing to compare the estimate with.
By their numbers in this assay, from the lowest: compound 2; then compounds 3 and 1 (each within the scatter of the next).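

Within the data shown here, compound 4 is reported as not active in this assay, with no number, so no step from compound 3 to compound 4 can be read. The compounds shown leave open how far apart these two stand. Nothing shown bears on the reason for this result.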